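Swapping tert-Butyl for Propyl on the Amide Nitrogen

The source may report more compounds than this note shows. Statements on the series, on what has been measured and on what is new or still open speak of the compounds shown alone.

Compound 1 `C=CC1=C(C(=O)NC(C)(C)C)C(c2ccc(OC)cc2)OC1`: in a functional assay on HeLa cells (Homo sapiens) for cytotoxicity, read by MTT assay, with a stated time of 24 h (on this read-out lower numbers stand for stronger inhibition and higher numbers for weaker inhibition), compound 1 gives > 100000 nM, which is a limit of the assay and not a number.
Compound 2 `C=CC1=C(C(=O)Nc2ccccc2)C(c2ccc(Cl)c(Cl)c2)OC1`: in this assay compound 2 gives > 100000 nM, again only a limit.
Compound 3 `C=CC1=C(C(=O)NC(C)(C)C)C(c2ccc(F)cc2)OC1`: in this assay compound 3 gives > 100000 nM, also only a limit.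

Compound 1 thus stands only at a limit, and so do the other two: the limit of > 100000 nM in this assay, at which 3 of the 3 values shown sit. Among the compounds with values here, the one pair that differs in a single place shows a step that the two limits leave unreadable from compound 1 to compound 3, so even that step cannot be sized. Compound 4 `C=CC1=C(C(=O)NCCC)C(c2ccc(OC)cc2)OC1` differs from compound 1 by propyl in place of tert-butyl on an amide-type nitrogen. No measured step touches the amide nitrogen, so nothing shown speaks for a change of any size in this assay in either direction. Compound 4 is expected to sit at the same limit, which means an expected step that the limit leaves unreadable from compound 1 to compound 4. The estimate for compound 4 is 150000 nM, between 30000 nM and 1000000 nM.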

Compound 4, half-maximal inhibitory concentration: 14000 nM
Compound 4: the middle estimate sits 11-fold (1.03 log units) above what was measured; the measured number lies below the stated range.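

In this assay, within the data shown here, the amide nitrogen is the first place in this set where a change gives a readable effect: propyl in place of tert-butyl produces an at least 7.1-fold lower number from compound 1 to compound 4 (0.85 log units; beyond the scatter), which means stronger inhibition. Since the starting point is only a limit, the true step could be larger. Compound 1, compound 2 and compound 3 all remain at one limit of the assay: the limit of > 100000 nM in this assay, at which 3 of the 4 values shown sit.

From the compounds shown here alone, whether a longer chain such as butyl, or an amine at the end of the propyl chain, would lower the number further stays open. So does whether propyl would have a similar effect on compound 3, which carries fluoro in place of methoxy.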